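Alkynyl uracils with a phthalimide side chain on MOLT-4 cells

A few compounds are considered here, and "the series" means these few. Any claim that something is new, unique, unknown or untested is made for them only; others in the source may bear on it.

Compound 1 `CCCCCCCCC#Cc1cn(C/C=C\CN2C(=O)c3ccccc3C2=O)c(=O)[nH]c1=O`: 36000 nM
Compound 2 `CCCCc1ccc(C#Cc2cn(C/C=C\CN3C(=O)c4ccccc4C3=O)c(=O)[nH]c2=O)cc1`: 31000 nM
Compound 3 `O=C1c2ccccc2C(=O)N1C/C=C\Cn1cc(C#CCCc2ccccc2)c(=O)[nH]c1=O`: 146000 nM

Three compounds share one core and differ only in the group on the triple-bonded carbon. In a functional assay on MOLT-4 cells (Homo sapiens) for antiproliferative activity, read by MTT assay, with a stated time of 3 days (on this read-out higher numbers stand for weaker inhibition and lower numbers for stronger inhibition), compound 1 gives 36000 nM and compound 2 gives 31000 nM, and the step of a 1.2-fold lower number from compound 1 to compound 2 (0.06 log units; within the scatter) lies within the scatter. Compound 3 gives 146000 nM, the highest of the three numbers, with a 4.1-fold higher number from compound 1 to compound 3 (0.61 log units; beyond the scatter) and a 4.7-fold higher number from compound 2 to compound 3 (0.67 log units; beyond the scatter) both beyond the scatter.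

Compound 4 `CCCCCc1ccc(C#Cc2cn(C/C=C\CN3C(=O)c4ccccc4C3=O)c(=O)[nH]c2=O)cc1` is the unmeasured member. It differs from compound 3 by 4-pentylphenyl in place of phenethyl on a triple-bonded carbon. The step that bears on this change is a 4.7-fold higher number from compound 2 to compound 3 (0.67 log units; beyond the scatter), which runs in the opposite direction, since 4-pentylphenyl differs from 4-butylphenyl only by the length of its chain; the step of a 1.2-fold lower number from compound 1 to compound 2 (0.06 log units; within the scatter) suggests that such a change in chain length matters little. Compound 4 is therefore expected to show a lower number in this assay than compound 3, near compound 2, a step of a 4.6-fold lower number from compound 3 to compound 4 (0.66 log units; beyond the scatter). The estimate for compound 4 in this assay is 32000 nM, within 15000 nM to 70000 nM.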

Compound 4, half-maximal inhibitory concentration: 30000 nM
Beside the measured number, compound 4's estimate is 1.1-fold (0.03 log units) above it, within the range that was stated.
By their numbers in this assay, from the lowest: compounds 4, 2 and 1 (each within the scatter of the next); then compound 3.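

With 4-pentylphenyl on the triple-bonded carbon, the number in this assay stays level with that of the 4-butylphenyl compound (a 1.0-fold lower number from compound 2 to compound 4 (0.01 log units; within the scatter)) and that of the octyl compound (a 1.2-fold lower number from compound 1 to compound 4 (0.08 log units; within the scatter)), so three different groups at this position now lie within the scatter of one another. The step to this group from phenethyl (a 4.9-fold lower number from compound 3 to compound 4 (0.69 log units; beyond the scatter)) lies beyond the scatter, which leaves compound 3 as the only one of the four set apart from the rest. Nothing shown accounts for this gap.

The compounds shown leave open whether a phenyl ring held on a shorter chain than the phenethyl of compound 3 would follow compound 3 or the other three. They also leave open how an amine or a carboxylic acid in place of the pentyl chain would change the number.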